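This account rests on a few compounds, and the source may have more. Where it says the series, first, only, none or still open, it means among the compounds named here.

Among the measured compounds shown here, compound 2 `COc1cccc(C(=O)CC2C(C#N)=C(N)Oc3ccc(Br)cc32)c1` gives 51.2% in a functional assay on MCF7 cells (Homo sapiens) for antiproliferative activity, read by sulforhodamine B assay, with a stated time of 72 h, tested at 10 uM (a higher number here means a weaker effect of the compound at the concentration tested, a lower number a stronger effect), the higher of the two numbers measured so far, while compound 1 `COc1cc(Br)cc2c1OC(N)=C(C#N)C2CC(=O)c1ccc(Br)cc1` gives 39.7% in this assay, lower by more than the usual scatter. Compound 3 `N#CC1=C(N)Oc2ccc(Br)cc2C1CC(=O)c1ccc(Br)cc1` differs from compound 2 in one place: 4-bromophenyl in place of 3-methoxyphenyl on a carbonyl carbon. Compound 1 carries the same 4-bromophenyl on its carbonyl carbon and gives 39.7%. On that basis a moderate downward step a number 8.2 percentage points lower from compound 2 to compound 3 (within the scatter) is expected in this assay. Compound 3 is estimated at 43% in this assay, within a range from 28% to 58%.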

Compound 3, a percentage reported as activity, at one concentration (the size of the read-out at that concentration, not a potency): 47.2%
Beside the measured number, compound 3's estimate is 4.2 percentage points below it; measured number inside the range.
By their numbers in this assay, from the lowest: compounds 1, 3 and 2 (each within the scatter of the next, the first and the last beyond it).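

In this assay the swap of 3-methoxyphenyl for 4-bromophenyl on a carbonyl carbon gives a number 4 percentage points lower from compound 2 to compound 3 (within the scatter) and so does not separate the two compounds. Hydrogen in place of methoxy on an aromatic carbon gives a number 7.5 percentage points higher from compound 1 to compound 3 (within the scatter) and does not separate them either, so neither single change is resolved in this read-out. No measurement here bears on why these steps came out as they did. As far as these compounds go, whether an amine or a carboxylic acid in place of the aromatic group on the carbonyl carbon would give a step beyond the scatter stays open. The same holds for a longer chain at that carbonyl carbon.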